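Extending the Alkynyl Chain on a Branched Nucleoside Core

A few compounds are considered here, and "the series" means these few. Any claim that something is new, unique, unknown or untested is made for them only; others in the source may bear on it.

Measured compounds:
compound 1, `CC[C@@]1(O)[C@@H](CO)O[C@@H](n2ccc(N)nc2=O)[C@@H]1O`: 269000 nM
compound 2, `CC#C[C@@]1(O)[C@@H](CO)O[C@@H](n2ccc(N)nc2=O)[C@@H]1O`: 24500 nM
compound 3, `CC#C[C@@]1(O)[C@@H](CO)O[C@@H](n2ccc(=O)[nH]c2=O)[C@@H]1O`: 354000 nM

All three were tested in a functional assay on L1210 cells (Mus musculus), read by MTT assay; on this read-out higher numbers stand for weaker inhibition and lower numbers for stronger inhibition. Compound 2 gives the lowest number of the three. Toward compound 2 the only single-point step is an 11-fold lower number from compound 1 to compound 2 (1.04 log units; beyond the scatter), and compound 3 sits higher still than compound 2, beyond the scatter.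

Compound 4, `CCC#C[C@@]1(O)[C@@H](CO)O[C@@H](n2ccc(N)nc2=O)[C@@H]1O`, differs from compound 2 in one place: methyl in place of hydrogen on a saturated chain carbon bound to a triple-bonded carbon. Among the compounds with values here, no measured step touches this place; the step of an 11-fold lower number from compound 1 to compound 2 (1.04 log units; beyond the scatter) exchanges the whole group on the ring carbon and so gives no direct guide. Compound 4 is therefore expected to sit close to compound 2, with a step of a 1.2-fold higher number from compound 2 to compound 4 (0.09 log units; within the scatter), not beyond the scatter. The estimate for compound 4 is 30000 nM, in the range 8000 nM to 110000 nM.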

Compound 4, half-maximal inhibitory concentration: 129000 nM
Compound 4: the middle estimate sits 4.3-fold (0.63 log units) below what was measured, outside the stated range (above it).
By their numbers in this assay, from the lowest: compound 2; then compound 4; then compounds 1 and 3 (each within the scatter of the next).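

In this assay the alkyne on the ring carbon proves sensitive to chain length: methyl in place of hydrogen on the saturated chain carbon gives a 5.3-fold higher number from compound 2 to compound 4 (0.72 log units; beyond the scatter) and so takes back much of what prop-1-yn-1-yl gained over ethyl. But-1-yn-1-yl still differs from ethyl, with a 2.1-fold lower number from compound 1 to compound 4 (0.32 log units; beyond the scatter) as a modest step in the same direction. No available evidence bears on this result. From the compounds shown here alone, whether a longer chain such as pent-1-yn-1-yl raises the number further stays open, as does the effect of an amine at the chain end.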